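Ethoxy to fluoro on the aryl ring: expected step

A few compounds are considered here, and "the series" means these few. Any claim that something is new, unique, unknown or untested is made for them only; others in the source may bear on it.

Compound 1 `Cc1ccc(C)c(N2CCN(C(=O)c3oc(C)nc3-c3ccccc3F)CC2)c1` gives 319 nM in a functional assay on HL-60 cells (Homo sapiens) for inhibition, read by MTT assay, with a stated time of 72 h; on this read-out higher numbers stand for weaker inhibition and lower numbers for stronger inhibition. For the measured compounds named here, compound 2 `CCOc1cccc(N2CCN(C(=O)c3oc(C)nc3-c3ccccc3)CC2)c1` gives 151 nM in this assay, the lowest of the two numbers so far; compound 1 sits at a higher number, a gap beyond the usual scatter. Going by the values given here, compounds 1 and 2 differ in more than one place, so no single step is read between them.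

Compound 3 `Cc1nc(-c2ccccc2)c(C(=O)N2CCN(c3cccc(F)c3)CC2)o1` has not yet been measured. It differs from compound 2 in one place: fluoro in place of ethoxy on an aromatic carbon. With no measured step of this kind in the series, the expectation rests on compound 2 alone at 151 nM; a small step, most likely toward a higher number or none beyond the scatter, is expected, a 1.7-fold higher number from compound 2 to compound 3 (0.24 log units; within the scatter). Compound 3 is therefore estimated at 260 nM in this assay, with a range from 110 nM to 650 nM.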

Compound 3, half-maximal inhibitory concentration: 45 nM
Beside the measured number, compound 3's estimate is 5.8-fold (0.76 log units) above it, outside the stated range (below it).
By their numbers in this assay, from the lowest: compound 3; then compound 2; then compound 1.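

In this assay, for the compounds shown here, this position on the six-membered aromatic ring of carbon only, meta to a large group, proves sensitive to its substituent: going from 3-ethoxyphenyl to 3-fluorophenyl gives a 3.4-fold lower number from compound 2 to compound 3 (0.53 log units; beyond the scatter), the first single-place step that can be read. The ethoxy group, with its oxygen and two-carbon chain, is therefore not required here for a low number on this read-out, and fluoro serves better in this one comparison. Nothing measured here bears on why the number falls.

Going by these compounds, whether the step reflects the loss of ethoxy or the arrival of fluoro remains open, and a chloro, methoxy or plain hydrogen at the same place would help separate the two. Steps involving compound 1 cannot be read, as it differs from both other compounds in more than one place.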